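The source may hold more compounds than are shown below. What is called first, only, known or untested is meant among the compounds shown, and "the series" means these compounds.

Compound 1 `O=[N+]([O-])c1ccccc1NS(=O)(=O)c1ccccc1` gives 22900 nM in a functional assay on PC-3 cells (Homo sapiens) for cytotoxicity, read by MTT assay, with a stated time of 5 days; a lower number here means a stronger inhibitor of growth, a higher number a weaker inhibitor of growth.
Compound 2 `Cc1ccc(NS(=O)(=O)c2ccc(F)cc2)c([N+](=O)[O-])c1` gives 850 nM in this assay.
Compound 3 `Cc1ccc(-c2nnn[nH]2)c(NS(=O)(=O)c2ccc(F)cc2)c1` reaches only > 100000 nM in this assay, which is a limit of the assay and not a number (the limit of > 100000 nM in this assay, at which 1 of the 3 values shown sits).

Of the two numbers measured, compound 2 stands lowest, and compound 1 lies well beyond the usual scatter away from it. Compound 3 gives a limit alone and so cannot be ranked against the others.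

Compound 4 `Cc1ccc(NS(=O)(=O)c2ccccc2)c([N+](=O)[O-])c1` differs from compound 2 in one place: hydrogen in place of fluoro on an aromatic carbon. For the measured compounds named here, no pair of measured compounds shows this same change, so the data give no direct guide to how a fluoro at that place affects the growth readout. The change removes a single heavy atom and brings in only a hydrogen, and the step expected from compound 2 to compound 4 a 1.4-fold higher number from compound 2 to compound 4 (0.15 log units; within the scatter) is small, within the scatter, with no firm direction. On that basis compound 4 is expected to give about 1200 nM in this assay, with a range from 400 nM to 4000 nM.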

Compound 4, concentration for 50% growth inhibition: 60300 nM
The estimate for compound 4 lay 50-fold (1.70 log units) below the measured number; measured number outside the range, above it.
By their numbers in this assay, from the lowest: compound 2; then compound 1; then compound 4. At a limit, above all of these: compound 3.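

Replacing the fluoro with hydrogen, on an aromatic carbon para to a large group, turns out to be a large change in this assay: going from 4-fluorophenyl to phenyl gives a 71-fold higher number from compound 2 to compound 4 (1.85 log units; beyond the scatter), so in this pair a single atom separates a strong inhibitor of growth from a much weaker one. The methyl shows a different picture, as methyl in place of hydrogen on an aromatic carbon, with no fluoro present in either compound, gives a 2.6-fold higher number from compound 1 to compound 4 (0.42 log units; beyond the scatter), a modest step in the weaker direction, so in this pair the methyl brings no gain on its own. Nothing measured in this set says why the fluoro counts for so much here.

The compounds shown leave open whether another group at this place, such as chloro, methoxy or an amine, would keep the number of compound 2 or lose it as compound 4 does. On these data alone, it also stays open whether fluoro at this place would count for as much on the core of compound 1, which lacks the methyl.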